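Methoxy on the fused ring: from ketone-linked to methylene-linked

The compounds below may be only part of what the source reports. "The series", "measured", "known", "first", "only" and "open" are said of these compounds alone.

Measured compounds:
compound 1 `COC(=O)c1[nH]c2ccccc2c1C(=O)c1cc(OC)c(OC)c(OC)c1N` 193 nM
compound 2 `COC(=O)c1[nH]c2ccc(OC)cc2c1C(=O)c1cc(OC)c(OC)c(OC)c1N` 102 nM
compound 3 `COc1cc(Cc2c[nH]c3ccccc23)c(N)c(OC)c1OC` 45000 nM

In a functional assay on MCF7 cells (Homo sapiens) for cytotoxicity, read by sulforhodamine B assay, with a stated time of 48 h (on this read-out lower numbers stand for stronger inhibition of growth and higher numbers for weaker inhibition of growth), compound 1 gives 193 nM. Compound 2 carries one change relative to compound 1, (methoxy in place of hydrogen on an aromatic carbon), and in this assay compound 2 gives 102 nM. The step is a 1.9-fold lower number from compound 1 to compound 2 (0.28 log units; within the scatter), so the two values cannot be told apart with confidence.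

Compound 3 stands on a different core, and the difference between the core of compound 3 and the core of compound 1 is not broken down here. In this assay compound 3 gives 45000 nM, the highest of the three numbers, and its gap to compound 1 and to compound 2 is far beyond the scatter.

Compound 4 `COc1ccc2c(Cc3cc(OC)c(OC)c(OC)c3N)c[nH]c2c1` has not yet been measured. It differs from compound 3 by methoxy in place of hydrogen on an aromatic carbon, the same change as from compound 1 to compound 2, at a place described in the same words. Because the earlier step was a 1.9-fold lower number from compound 1 to compound 2 (0.28 log units; within the scatter), the step from compound 3 to compound 4 is expected to be of similar size and to lie within the scatter as well, that is a 1.6-fold lower number from compound 3 to compound 4 (0.21 log units; within the scatter); this rests on one pair only, and the two cores differ widely, so the expectation is loose. Compound 4 is therefore estimated to give 28000 nM in this assay, between 10000 nM and 75000 nM.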

Compound 4, concentration for 50% growth inhibition: 1830 nM
Compound 4: the middle estimate sits 15-fold (1.18 log units) above what was measured; measured number below the stated range.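

In this assay, methoxy in place of hydrogen on an aromatic carbon produced a 25-fold lower number from compound 3 to compound 4 (1.39 log units; beyond the scatter), so on this core the change is large. Set beside the earlier pair, the same change did not carry over in size from one core to the other, and only the new step lies beyond the scatter: the same change on two cores in this assay, a 1.9-fold lower number (0.28 log units; within the scatter) from compound 1 to compound 2 and a 25-fold lower number (1.39 log units; beyond the scatter) from compound 3 to compound 4, 13-fold (1.11 log units) apart, beyond the scatter of two such steps This shows that, for these two pairs, the size of the methoxy step cannot simply be transferred between cores, but it does not show why, since the two cores differ in more than one place and the data do not single out which difference matters, and two pairs give no general rule for the series.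

The compounds shown leave open whether another group in the same place on the core of compound 3, such as hydroxy, ethoxy or fluorine, would produce a step as large as that of methoxy. They also leave open whether methoxy on another aromatic carbon of the same ring would do so, and whether a third core would follow the pair of compound 1 and compound 2 or the pair of compound 3 and compound 4.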